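The source may hold more compounds than are shown below. What is called first, only, known or untested is meant among the compounds shown, and "the series" means these compounds.

Among the measured compounds shown here, compound 1 `CCCCc1ccc(CN(Cc2ccccc2)S(C)(=O)=O)c(=O)n1Cc1ccc(-c2ccccc2-c2nn[nH]n2)cc1` is one of two compounds measured in a functional assay (aorta) for antagonist activity, with Oryctolagus cuniculus as the target (on this read-out higher numbers stand for weaker inhibition and lower numbers for stronger inhibition), where compound 1 gives 2 nM, the lowest of the two numbers. For the measured compounds named here, its companion, compound 2 `CCCCc1ccc(CNS(=O)(=O)c2ccccc2)c(=O)n1Cc1ccc(-c2ccccc2-c2nn[nH]n2)cc1`, gives 7 nM in this assay; the only step measured so far, a 3.5-fold higher number from compound 1 to compound 2 (0.54 log units; beyond the scatter), shows that swapping one substituted amino group for another on the saturated chain carbon bound to an aromatic carbon costs a modest amount of potency.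

Compound 3 `CCCCc1ccc(CN)c(=O)n1Cc1ccc(-c2ccccc2-c2nn[nH]n2)cc1` has not yet been measured. It differs from compound 1 at that same place: amino in place of benzyl(methylsulfonyl)amino on a saturated chain carbon bound to an aromatic carbon. This is a much larger change than the step from compound 1 to compound 2, since the whole benzyl(methylsulfonyl)amino group, with its six-membered aromatic ring of carbon only, is removed and only a bare amino remains.

Going by the values given here, only the step from compound 1 to compound 2 bears on this, and it was modest; a larger loss is therefore expected here, with compound 3 estimated at 150 nM in this assay, within 20 nM to 1200 nM, corresponding to an expected step of a 75-fold higher number from compound 1 to compound 3 (1.88 log units; beyond the scatter).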

Compound 3, half-maximal inhibitory concentration: 20 nM
Compound 3: middle estimate off by 7.5-fold (0.88 log units), on the high side; the measured number falls inside the stated range.
By their numbers in this assay, from the lowest: compound 1; then compound 2; then compound 3.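

Amino in place of benzyl(methylsulfonyl)amino gives a 10-fold higher number from compound 1 to compound 3 (1.00 log units; beyond the scatter) in this assay on the saturated chain carbon bound to an aromatic carbon. Compound 3 still gives 20 nM with only one heavy atom left in that place, so the ring and the sulfonyl part of the larger group are not required for a low number in this series. Taking only the phenylsulfonyl off the amine nitrogen gives a 2.9-fold higher number from compound 2 to compound 3 (0.46 log units; beyond the scatter), which means that both sulfonyl-bearing amino groups give lower numbers than the bare amino, while the gain each one brings remains modest. No measurement offered here accounts for these differences.

From the compounds shown here alone, it remains open which part of the benzyl(methylsulfonyl)amino group carries its advantage, since a benzylamino group or a methylsulfonylamino group on the same carbon would separate the contribution of the benzyl from that of the methylsulfonyl. Going by these compounds, it is also open whether the nitrogen itself matters in this place, which a hydroxyl group or a plain methyl group at the same point would help to show.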